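From 3-hydroxypropyl to 4-acetylbutyl on a shared core

The source may report more compounds than this note shows. Statements on the series, on what has been measured and on what is new or still open speak of the compounds shown alone.

Compound 1 `CCCn1c(=O)n(CCN(C)C)c(=O)c2[nH]cnc21`: 2700 nM
Compound 2 `CCCn1c(=O)n(CCCN(C)C)c(=O)c2[nH]cnc21`: 20500 nM
Compound 3 `CCCn1c(=O)n(CCCO)c(=O)c2[nH]cnc21`: 5100 nM

All three values come from a functional assay (trachea) with Cavia porcellus as the target; on this read-out lower numbers stand for an effect already at smaller amounts and higher numbers for an effect only at larger amounts of compound. Compound 3 lies close to compound 1, as a 1.9-fold higher number from compound 1 to compound 3 (0.28 log units; within the scatter) shows, while a 4.0-fold lower number from compound 2 to compound 3 (0.60 log units; beyond the scatter) separates it clearly from compound 2.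

The next structure is compound 4 `CCCn1c(=O)n(CCCCC(C)=O)c(=O)c2[nH]cnc21`, and the change is 2-oxopropyl in place of hydroxy on a saturated chain carbon, three bonds along the chain from an aromatic nitrogen. The same difference can be read as 3-hydroxypropyl to 4-acetylbutyl.

Within the data shown here, no measured pair shows this exact swap, so the evidence is indirect. The nearest guides are the other changes at the chain end. Two were modest, a 7.6-fold higher number from compound 1 to compound 2 (0.88 log units; beyond the scatter) and a 4.0-fold lower number from compound 2 to compound 3 (0.60 log units; beyond the scatter), and they ran in opposite directions. The third, a 1.9-fold higher number from compound 1 to compound 3 (0.28 log units; within the scatter), stayed within the scatter. Together they give no firm direction, so no step beyond the scatter is expected in this assay, although a modest step either way remains possible. The estimated change is a 1.1-fold lower number from compound 3 to compound 4 (0.05 log units; within the scatter). For compound 4 the estimated value is 4500 nM, with an expected range from 1500 nM to 14000 nM.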

Compound 4, half-maximal effective concentration: 60 nM
For compound 4 the middle estimate is 75-fold (1.88 log units) above the measured one, outside the stated range (below it).
By their numbers in this assay, from the lowest: compound 4; then compounds 1 and 3 (each within the scatter of the next); then compound 2.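

In this assay, among these compounds, the switch from 3-hydroxypropyl to 4-acetylbutyl gives an 85-fold lower number from compound 3 to compound 4 (1.93 log units; beyond the scatter) and is the first large step at this position, whereas the earlier changes at the chain end were modest or stayed within the scatter. The 4-acetylbutyl chain also sets compound 4 far apart from the two dimethylamino compounds, with a 340-fold lower number from compound 2 to compound 4 (2.53 log units; beyond the scatter) and a 45-fold lower number from compound 1 to compound 4 (1.65 log units; beyond the scatter) in the same assay, so compound 4 has the lowest number of the four. This position can therefore shift the number much further than the first three compounds suggested, although no measurement shown here explains the size of this shift.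

This change lengthens the chain and replaces the hydroxy end with an acetyl end in a single step, so the compounds shown cannot tell which of the two accounts for the gain; a 4-hydroxybutyl chain or a plain pentyl chain would separate them. Also open, on these data alone, is how the number would respond to a carboxylic acid at the chain end or to a still longer chain carrying the acetyl group.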